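Fluoro-to-chloro swap: from compound 3 to compound 4

The compounds below may be only part of what the source reports. "The series", "measured", "known", "first", "only" and "open" are said of these compounds alone.

Compound 1 `O=C(/C=C/c1cccc(F)c1)NCCO` gives 17 mg/kg in a functional assay on the whole organism (strain Kunming) with Mus musculus as the target, in the maximal electroshock model; a lower number here means that less compound is needed, a higher number that more compound is needed for the effect. Compound 2 `O=C(/C=C/c1cccc(Cl)c1)NCCO` gives 25 mg/kg in this assay; the change from compound 1 to compound 2 is chloro in place of fluoro on an aromatic carbon, and the step is a 1.5-fold higher number from compound 1 to compound 2 (0.17 log units; within the scatter). Compound 3 `O=C(/C=C/c1ccccc1F)NCCO` gives 35.3 mg/kg in this assay; its gap to compound 1 lies beyond the scatter, its gap to compound 2 within it. The difference between the core of compound 1 and the core of compound 3 is not broken down here. Compound 4 `O=C(/C=C/c1ccccc1Cl)NCCO` is not yet measured; its change from compound 3 is chloro in place of fluoro on an aromatic carbon. This is the same kind of change as from compound 1 to compound 2, not the same one: there the place is meta to a group of 8 heavy atoms, here it is ortho to a group of 8 heavy atoms. For compound 4 a step of about a 1.3-fold higher number from compound 3 to compound 4 (0.11 log units; within the scatter) in this assay is expected, resting on the step of a 1.5-fold higher number from compound 1 to compound 2 (0.17 log units; within the scatter). Compound 4 is estimated at 45 mg/kg, between 25 mg/kg and 80 mg/kg.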

Compound 4, dose for half-maximal effect: 59 mg/kg
Estimate against measurement, compound 4: 1.3-fold (0.12 log units) below, within the range that was stated.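

In this assay the swap of fluoro for chloro gives a 1.7-fold higher number from compound 3 to compound 4 (0.22 log units; within the scatter), and beside the earlier step it shows no difference between the two cores: the same change on two cores in this assay, a 1.5-fold higher number (0.17 log units; within the scatter) from compound 1 to compound 2 and a 1.7-fold higher number (0.22 log units; within the scatter) from compound 3 to compound 4, 1.1-fold (0.06 log units) apart, within the scatter of two such steps. Within the data shown here, each step lies within the scatter on its own, so the agreement shows only that this change left no measurable shift on either core. It does not show a real effect of the swap, and two cores in one assay give no rule for other cores in the series.

Open, as far as these compounds go, is whether other groups on the aromatic ring, such as bromo, methyl or trifluoromethyl, would follow the same course. Also open, from the compounds shown here alone, is the effect of changes away from that ring, such as a longer chain or an amine in place of the hydroxyl.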